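Benzyloxy to ethoxy on the core of compound 1

The source may hold more compounds than are shown below. What is called first, only, known or untested is meant among the compounds shown, and "the series" means these compounds.

Measured compounds:
compound 1 `CN(C)CCNc1ccnc2cc(OCc3ccccc3)ccc12` — 3120 nM
compound 2 `Clc1ccnc2cc(OCc3ccccc3)ccc12` — 2680 nM
compound 3 `CN(C)CCCNc1ccnc2cc(OCc3ccc(F)cc3)ccc12` — 1570 nM

In a functional assay on HepG2 cells (Homo sapiens) for cytotoxicity, read by MTT assay, with a stated time of 48 h (on this read-out higher numbers stand for weaker inhibition and lower numbers for stronger inhibition), compound 1 gives 3120 nM, the highest number of the three, though every neighbour lies within the scatter. Among the compounds with values here, its nearest neighbour is compound 2, and the one single-point step available, a 1.2-fold lower number from compound 1 to compound 2 (0.07 log units; within the scatter), sits within the scatter. Compound 3 differs from compound 1 in more than one place, so only the two values can be set side by side: compound 3 gives 1570 nM, again within the scatter of compound 1.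

Compound 4 `CCOc1ccc2c(NCCN(C)C)ccnc2c1` differs from compound 1 by methyl in place of phenyl on a saturated chain carbon bound to an oxygen on an aromatic ring. Within the data shown here, no measured step touches this part of the molecule; the only step known changes the amino side chain, not the ether, and is itself within the scatter. There is therefore no basis for a directional shift, and the step of a 1.1-fold higher number from compound 1 to compound 4 (0.05 log units; within the scatter) is expected to stay within the scatter. For compound 4 the estimate in this assay is 3500 nM, with a range from 1500 nM to 8000 nM.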

Compound 4, half-maximal inhibitory concentration: 5680 nM
Compound 4: the middle estimate sits 1.6-fold (0.21 log units) below what was measured; the measured number falls inside the stated range.
By their numbers in this assay, from the lowest: compounds 3, 2, 1 and 4 (each within the scatter of the next, the first and the last beyond it).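

In this assay, within the data shown here, the replacement of benzyloxy by ethoxy gives a 1.8-fold higher number from compound 1 to compound 4 (0.26 log units; within the scatter) and provides the first single-place reading at the ether, as the earlier step changed only the amino side chain. The phenyl, with its six-membered aromatic ring of carbon only, can thus give way to methyl on this saturated chain carbon without a shift beyond the scatter, so this ring is not needed to retain a number in this range on the core of compound 1. No measurement on hand explains this step or links it to any property of either group.

From the compounds shown here alone, whether a longer chain such as butyl, or a terminal amine or carboxylic acid on the ethoxy chain, would leave the number within the scatter remains open. Also open, going by these compounds, is whether ethoxy would read the same on compound 2, which carries chloro in place of the amino side chain.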